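This account rests on a few compounds, and the source may have more. Where it says the series, first, only, none or still open, it means among the compounds named here.

Measured so far:

compound 1, `CCOC(=O)COC(=O)NCCCC(C)Nc1cc(OC)cc2cccnc12`: 3.09
compound 2, `COc1cc(NC(C)CCCNC(=O)Oc2ccccc2)c2ncccc2c1`: 4.27

Within the data shown here, in a physicochemical assay for lipophilicity, read by HPLC, in phosphate buffer, measured as octanol-water partition, with a stated time of 30 min, at pH 7.4 (on this read-out lower numbers stand for lower lipophilicity and higher numbers for higher lipophilicity), compound 2 holds the higher of the two numbers; its nearest neighbour is compound 1, and the single measured step, a number 1.18 log units higher from compound 1 to compound 2 (beyond the scatter), puts the two well beyond the scatter. Both carry the same core and the same carbamate linkage, and the only difference sits on the oxygen next to the carbonyl group.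

Compound 3, `COc1cc(NC(C)CCCNC(=O)OCC(F)(F)F)c2ncccc2c1`, keeps that arrangement and differs from compound 2 by 2,2,2-trifluoroethyl in place of phenyl on an oxygen next to a carbonyl group. Among the measured compounds shown here, no measured pair covers a phenyl-to-2,2,2-trifluoroethyl exchange, so the expectation rests on the one step at this oxygen, a number 1.18 log units higher from compound 1 to compound 2 (beyond the scatter), which shows that the group on this position moves this assay by a large amount. The 2,2,2-trifluoroethyl group is smaller than phenyl by one heavy atom and has no ring, so a downward step is expected, but a smaller one than the measured step. The expected step is a number 0.57 log units lower from compound 2 to compound 3 (beyond the scatter). For compound 3 the estimate in this assay is 3.7, with a range of 3.3 to 4.1.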

Compound 3, distribution coefficient: 3.41
For compound 3 the middle estimate is 0.29 log units above the measured one, within the range that was stated.
By their numbers in this assay, from the lowest: compound 1; then compound 3; then compound 2.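

In this assay, the exchange of phenyl for 2,2,2-trifluoroethyl on this oxygen (a number 0.86 log units lower from compound 2 to compound 3 (beyond the scatter)) gives a second measured step at this position, and it shows that the phenyl-bearing compound 2 stays highest against two different groups without a ring. Those two ring-free compounds also separate from each other, since trifluoromethyl in place of ethoxycarbonyl on the saturated chain carbon bound to this oxygen still moves the number (a number 0.32 log units higher from compound 1 to compound 3 (beyond the scatter)), so the three groups give three distinct levels and, among these three compounds, none goes against the order of phenyl above both ring-free groups. Nothing at hand gives a reason for these differences.

With only one ring-bearing group at this position, the compounds shown cannot separate the presence of a ring from the other features of phenyl, and a cyclohexyl or benzyl group on the same oxygen would bear on that. From the compounds shown here alone, how an amine, a carboxylic acid or a longer unfluorinated alkyl chain there would read in this assay also stays open.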